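Fluoro for methyl on a weakly antiproliferative diamino-pyrimidine series

A few compounds are considered here, and "the series" means these few. Any claim that something is new, unique, unknown or untested is made for them only; others in the source may bear on it.

Measured so far:
compound 1 `Cc1ccc2nc(Nc3nc(Nc4ccc(S(C)(=O)=O)cc4)ncc3F)sc2c1`: 17200 nM
compound 2 `CS(=O)(=O)c1ccc(Nc2ncc(F)c(Nc3nc4ccc(F)cc4s3)n2)cc1`: > 50000 nM
compound 3 `COc1ccc2nc(Nc3nc(Nc4ccc(S(N)(=O)=O)cc4)ncc3C)sc2c1`: 36700 nM

Of the compounds shown here, three have been tested in a functional assay on HeLa cells (Homo sapiens) for antiproliferative activity, read by MTT assay, with a stated time of 48 h; on this read-out lower numbers stand for stronger inhibition and higher numbers for weaker inhibition. Compound 1 gives 17200 nM in this assay. For compound 2 this assay reports only a limit, > 50000 nM, as noted at the limit of > 50000 nM in this assay, at which 1 of the 3 values shown sits. Compound 3 gives 36700 nM, the higher of the two numbers, with compound 1 as its nearest neighbour. The difference between the core of compound 1 and the core of compound 3 is not broken down here.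

Between compound 1 and compound 2 the change is fluoro in place of methyl on an aromatic carbon, and it produced an at least 2.9-fold higher number from compound 1 to compound 2 (0.46 log units; beyond the scatter). Compound 4 `COc1ccc2nc(Nc3nc(Nc4ccc(S(N)(=O)=O)cc4)ncc3F)sc2c1`, not yet measured, carries the same kind of change relative to compound 3: fluoro in place of methyl on an aromatic carbon. The surroundings differ, however: in compound 2 the fluoro sits on a six-membered aromatic ring of carbon only, part of a fused system, meta and para to a fused ring, whereas in compound 4 it sits on a six-membered aromatic ring with 2 nitrogen, ortho and para to a large group, two atoms from the ring nitrogen.

Because the earlier step of an at least 2.9-fold higher number from compound 1 to compound 2 (0.46 log units; beyond the scatter) weakened activity, compound 4 is expected to be no stronger than compound 3, with an estimated step of a 1.3-fold higher number from compound 3 to compound 4 (0.12 log units; within the scatter). Compound 4 is therefore estimated at 48000 nM in this assay, within 18000 nM to 120000 nM.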

Compound 4, half-maximal inhibitory concentration: 13000 nM
The estimate for compound 4 lay 3.7-fold (0.57 log units) above the measured number; the measured number lies below the stated range.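

In this assay, fluoro in place of methyl on an aromatic carbon gave a 2.8-fold lower number from compound 3 to compound 4 (0.45 log units; beyond the scatter), whereas the same kind of change had weakened activity on the earlier pair. The outcome on one core therefore did not carry over to the other, with the two steps running in opposite directions: the same change on two cores in this assay, an at least 2.9-fold higher number (0.46 log units; beyond the scatter) from compound 1 to compound 2 and a 2.8-fold lower number (0.45 log units; beyond the scatter) from compound 3 to compound 4, at least 8.2-fold (0.91 log units) apart, beyond the scatter of two such steps. Compound 2 carries only a limit, so the earlier step has no exact size, and the two pairs show that the direction can differ between cores but not what sets it: the limit of > 50000 nM in this assay, at which 1 of the 4 values shown sits.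

The compounds shown leave open how a chloro group or a nitrile on that aromatic carbon would compare with methyl and fluoro on the core of compound 3. Also open, as far as these compounds go, is whether the opposite outcomes depend on the ring that carries the change or on the other groups of the two cores, as the two pairs differ in both.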